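Series notes: compound 3 to compound 4, growth inhibition

The compounds below may be only part of what the source reports. "The series", "measured", "known", "first", "only" and "open" are said of these compounds alone.

Compound 1 `O=C(/C=C/c1ccccc1Oc1ncnc2ccc(Cl)cc12)/C=C/c1cccc(Cl)c1Cl` and compound 2 `O=C(/C=C/c1ccccc1Oc1ncnc2ccc(Cl)cc12)/C=C/c1c(Cl)cccc1Cl` share a core that compound 3 `O=C(/C=C/c1ccc(Oc2ncnc3ccc(Cl)cc23)cc1)/C=C/c1ccc(Cl)c(Cl)c1` varies. In a functional assay on PC-3 cells (Homo sapiens) for inhibition, read by MTT assay, with a stated time of 72 h, tested at 10 uM (a higher number here means more inhibition of growth at the concentration tested, a lower number less inhibition of growth), compound 1 gives 73.8%, compound 2 gives 70.1% and compound 3 gives 33.5%, the lowest of the three numbers, beyond the scatter from both compound 2 and compound 1. Within the data shown here, the one single-point step recorded is the aryl exchange a number 3.7 percentage points lower from compound 1 to compound 2 (within the scatter), which stayed within the scatter.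

Compound 4 `O=C(/C=C/c1ccc(Oc2ncnc3ccc(Cl)cc23)cc1)/C=C/c1cc([N+](=O)[O-])ccc1Cl` differs from compound 3 by 2-chloro-5-nitrophenyl in place of 3,4-dichlorophenyl on a double-bonded chain carbon bound to a double-bonded chain carbon. Only the aryl exchange a number 3.7 percentage points lower from compound 1 to compound 2 (within the scatter) bears on this, and it was small, so no step beyond the scatter is expected in this assay. Compound 4 is estimated at 35% with a range of 18% to 55%. The expected step is a number 1.5 percentage points higher from compound 3 to compound 4 (within the scatter).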

Compound 4, percent growth inhibition at one concentration: 76.8%
The estimate for compound 4 lay 41.8 percentage points below the measured number; the whole stated range lies below it.
By their numbers in this assay, from the lowest: compound 3; then compounds 2, 1 and 4 (each within the scatter of the next).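

In this assay, this aryl position proves sensitive to the group it carries: 2-chloro-5-nitrophenyl in place of 3,4-dichlorophenyl gives a number 43.3 percentage points higher from compound 3 to compound 4 (beyond the scatter), whereas the earlier exchange, on the core of compound 1, gave only a number 3.7 percentage points lower from compound 1 to compound 2 (within the scatter). The entering group carries hydrogen-bond acceptors that the leaving group lacks, but this difference is not shown to account for the step. Nothing measured here explains the step.

From the compounds shown here alone, the nitro group and the changed chlorine pattern enter together, so their separate shares remain open. Going by these compounds, whether an amine or a carboxylic acid in place of the nitro group would keep the higher number also remains open.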